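This account rests on a few compounds, and the source may have more. Where it says the series, first, only, none or still open, it means among the compounds named here.

Compound 1 `CCOCCOC(=O)C(=O)Nc1nc(-c2cc(OCc3ccccc3)no2)cs1` gives 3.7 mg/kg
Compound 2 `CCOCCOC(=O)C(=O)Nc1nc(-c2cc(COC)no2)cs1` gives 2.4 mg/kg
Compound 3 `CCOCCOC(=O)C(=O)Nc1nc(-c2cc(C(=O)OCC)no2)cs1` gives 0.08 mg/kg

All three numbers come from a functional assay on the whole organism with Rattus norvegicus as the target (a lower number here means that less compound is needed, a higher number that more compound is needed for the effect), in which compound 2 stands at 2.4 mg/kg as its starting point here. Two steps fix its place (a 1.5-fold lower number from compound 1 to compound 2 (0.19 log units; within the scatter)) and (a 30-fold lower number from compound 2 to compound 3 (1.48 log units; beyond the scatter)), so its number lies close to that of compound 1 and far from that of compound 3.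

Compound 4 `CCOCCOC(=O)C(=O)Nc1nc(-c2cc(CO)on2)cs1` has 5-(hydroxymethyl)-1,2-oxazol-3-yl in place of 3-(methoxymethyl)-1,2-oxazol-5-yl on the shared core (5-(hydroxymethyl)-1,2-oxazol-3-yl in place of 3-(methoxymethyl)-1,2-oxazol-5-yl on an aromatic carbon).

The nearest guides are the swaps of the group on that ring. Methoxymethyl in place of benzyloxy was the small step above. Both large steps bring in ethoxycarbonyl, as does the one from benzyloxy (a 46-fold lower number from compound 1 to compound 3 (1.67 log units; beyond the scatter)), and compound 4 carries no such group. Among the measured compounds shown here, no measured compound has a hydroxymethyl or this other attachment of the ring, so the uncertainty is wide. The expected step therefore stays within the scatter (a 1.6-fold lower number from compound 2 to compound 4 (0.20 log units; within the scatter)). For compound 4 the expected value is 1.5 mg/kg (estimated range 0.3 mg/kg to 7 mg/kg).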

Compound 4, dose for half-maximal effect: 1.8 mg/kg
Compound 4: the middle estimate sits 1.2-fold (0.08 log units) below what was measured; the range from low to high includes it.
By their numbers in this assay, from the lowest: compound 3; then compounds 4, 2 and 1 (each within the scatter of the next, the first and the last beyond it).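

In this assay, placing 5-(hydroxymethyl)-1,2-oxazol-3-yl where 3-(methoxymethyl)-1,2-oxazol-5-yl stood gives a 1.3-fold lower number from compound 2 to compound 4 (0.12 log units; within the scatter), so the two numbers cannot be told apart. This shows that a group carrying a hydrogen-bond donor, with the ring joined through a different ring atom, still gives a number in the same range as compound 2. Nothing measured here explains why the two numbers are so alike.

Since the side chain and the ring attachment differ together, the step cannot show what each does alone, and the two could cancel each other out. Also open, going by these compounds, is how the 5-substituted 1,2-oxazol-3-yl ring would behave with ethoxycarbonyl, the group of compound 3 at 0.08 mg/kg, or with a carboxylic acid or an amine.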